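Naphthalene in Place of Methoxyphenyl on a Flat Scaffold

A few compounds are considered here, and "the series" means these few. Any claim that something is new, unique, unknown or untested is made for them only; others in the source may bear on it.

Measured compounds:
compound 1, `c1ccc(-c2cn3ccnc3c(-c3ccc4ncn(C5CCCCC5)c4c3)n2)cc1`: -11.1%
compound 2, `COc1ccc(-c2cn3ccnc3c(-c3ccc4ncn(C5CCCCC5)c4c3)n2)cc1`: -8.6%

In a functional assay on T47D cells (Homo sapiens) for inhibition, read by sulforhodamine B assay, with a stated time of 48 h, tested at 10 uM (a higher number here means more inhibition at the concentration tested (going by the name of the read-out), a lower number less inhibition), compound 1 gives -11.1%, and compound 2 gives -8.6%. For the measured compounds named here, both values are negative, so neither compound inhibits growth at the concentration tested, and the two lie within the scatter of each other; the only measured step, a number 2.5 percentage points higher from compound 1 to compound 2 (within the scatter), confirms this. Compound 3, `c1ccc2c(-c3cn4ccnc4c(-c4ccc5ncn(C6CCCCC6)c5c4)n3)cccc2c1`, has not yet been measured in this assay. It differs from compound 2 as follows: naphthalen-1-yl in place of 4-methoxyphenyl on an aromatic carbon. The step from compound 1 to compound 2 is the only one that touches the same position, and it changed nothing beyond the scatter, but it altered far less of the structure than the present change does. With both measured values near zero, the expected step is a number 3.6 percentage points higher from compound 2 to compound 3 (within the scatter), that is, none beyond the scatter. Compound 3 is therefore estimated at -5%, in the range -25% to 15%.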

Compound 3, a percentage reported as inhibition, at one concentration (the size of the read-out at that concentration, not a potency): 41.3%
For compound 3 the middle estimate is 46.3 percentage points below the measured one; the measured number lies above the stated range.
By their numbers in this assay, from the lowest: compounds 1 and 2 (each within the scatter of the next); then compound 3.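

In this assay this position proves far from indifferent: there is a number 49.9 percentage points higher from compound 2 to compound 3 (beyond the scatter) when naphthalen-1-yl replaces 4-methoxyphenyl, and a number 52.4 percentage points higher from compound 1 to compound 3 (beyond the scatter) when it replaces phenyl. Adding a methoxy group to the phenyl ring had not revealed this sensitivity, whereas a group with two six-membered aromatic rings of carbon turns a reading with no inhibition into clear inhibition at the concentration tested. No measurement at hand explains why this exchange has so large an effect.

Only phenyl, 4-methoxyphenyl and naphthalen-1-yl are shown at this position, so it remains open how other groups, such as an amine, a carboxylic acid or a longer alkyl chain, would fare there. A reading at one concentration also leaves the potency of compound 3 unknown.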